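Shifting Chlorine Positions on a Dichlorophenyl Group

This account rests on a few compounds, and the source may have more. Where it says the series, first, only, none or still open, it means among the compounds named here.

Of the compounds shown here, three built on a shared core have been measured in a functional assay on HT-29 cells (Homo sapiens) for cytotoxicity, read by MTT assay, with a stated time of 72 h; on this read-out lower numbers stand for stronger inhibition and higher numbers for weaker inhibition. Compound 1 `CN(C)CCn1cnnc1-c1cc(Oc2ccc(NC(=O)N/N=C/c3ccc(Cl)cc3Cl)cc2F)ccn1` gives 390 nM. Compound 2 `CN(C)CCn1cnnc1-c1cc(Oc2ccc(NC(=O)N/N=C/c3c(Cl)cccc3Cl)cc2F)ccn1` gives 280 nM, the lowest of the three numbers, although the step of a 1.4-fold lower number from compound 1 to compound 2 (0.14 log units; within the scatter) stays within the scatter. Compound 3 `CN(C)CCn1cnnc1-c1cc(Oc2ccc(NC(=O)N/N=C/c3ccccc3O[N+](=O)[O-])cc2F)ccn1` gives 950 nM, and the steps of a 2.4-fold higher number from compound 1 to compound 3 (0.39 log units; beyond the scatter) and a 3.4-fold higher number from compound 2 to compound 3 (0.53 log units; beyond the scatter) are modest. Compound 4 `CN(C)CCn1cnnc1-c1cc(Oc2ccc(NC(=O)N/N=C/c3cccc(Cl)c3Cl)cc2F)ccn1` has not yet been measured; it differs from compound 2 by 2,3-dichlorophenyl in place of 2,6-dichlorophenyl on a carbon with a double bond to nitrogen. For the measured compounds named here, the only measured step that bears on this change is a 1.4-fold lower number from compound 1 to compound 2 (0.14 log units; within the scatter), where the two chlorine atoms were likewise rearranged on the same phenyl ring and the number hardly moved; the other two steps swap the dichlorophenyl for a 2-(nitrooxy)phenyl, a different kind of change. With one chlorine simply moved again, no step beyond the scatter is expected, and the expected step is a 1.3-fold higher number from compound 2 to compound 4 (0.10 log units; within the scatter). Compound 4 is therefore estimated at 350 nM, with a range from 150 nM to 800 nM.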

Compound 4, half-maximal inhibitory concentration: 130 nM
Compound 4: the middle estimate sits 2.7-fold (0.43 log units) above what was measured; measured number below the stated range.
By their numbers in this assay, from the lowest: compound 4; then compounds 2 and 1 (each within the scatter of the next); then compound 3.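

In this assay, the arrangement of the two chlorine atoms on this phenyl ring matters: with the atoms and counts unchanged, 2,3-dichlorophenyl in place of 2,6-dichlorophenyl gives a 2.2-fold lower number from compound 2 to compound 4 (0.33 log units; beyond the scatter), and in place of 2,4-dichlorophenyl it gives a 3.0-fold lower number from compound 1 to compound 4 (0.48 log units; beyond the scatter). The earlier rearrangement, a 1.4-fold lower number from compound 1 to compound 2 (0.14 log units; within the scatter), could not show this, whereas the new arrangement stands apart from both other dichlorophenyl groups and also from the 2-(nitrooxy)phenyl group, with a 7.3-fold lower number from compound 3 to compound 4 (0.86 log units; beyond the scatter). No separate measurement is available to explain why this arrangement gives the lowest number.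

As far as these compounds go, it remains open whether chlorine itself is needed here, or whether methyl groups or bromine atoms in the same arrangement would give a similar number. From the compounds shown here alone, the effect of a single chlorine atom on this ring also remains unknown.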